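A few compounds are considered here, and "the series" means these few. Any claim that something is new, unique, unknown or untested is made for them only; others in the source may bear on it.

Measured compounds:
- compound 1, `COc1cc(Cl)cc(-c2nn(-c3cccc(NC(=O)Nc4cccc(C(F)(F)F)c4)c3)cc2-c2ccncc2)c1`, in a functional assay on KM12 cells (Homo sapiens) for inhibition, read by sulforhodamine B assay, with a stated time of 48 h, tested at 10 uM (on this read-out higher numbers stand for a weaker effect at the one concentration tested and lower numbers for a stronger effect), gives 9.81%
- compound 2, `COc1cc(Cl)cc(-c2nn(-c3cccc(NC(=O)c4cccc(C(F)(F)F)c4)c3)cc2-c2ccncc2)c1`, gives 43.7%
- compound 3, `COc1cc(Cl)cc(-c2nn(-c3cccc(NC(=O)Nc4ccc(Cl)c(Cl)c4)c3)cc2-c2ccncc2)c1`, gives 14.4%

Compound 1 has the lowest number of the three; compound 3 lies nearest to it, a number 4.6 percentage points higher from compound 1 to compound 3 (within the scatter), and compound 2 lies furthest, a number 33.9 percentage points higher from compound 1 to compound 2 (beyond the scatter). Among the compounds with values here, the one step that changes the carbonyl from a urea to an amide is the only step beyond the scatter; the other, which exchanges one aryl group for another on the amide-type nitrogen, stays within it.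

Compound 4, `COc1cc(Cl)cc(-c2nn(-c3cccc(NC(=O)Nc4cc(C(F)(F)F)cc(C(F)(F)F)c4)c3)cc2-c2ccncc2)c1`, keeps the urea of compound 1 and differs from it only on the aryl ring attached to the amide-type nitrogen: trifluoromethyl in place of hydrogen on an aromatic carbon. Within the data shown here, the step that bears most directly on this change is the one from compound 1 to compound 3, where a different substitution of the same aryl ring gave a number 4.6 percentage points higher from compound 1 to compound 3 (within the scatter). The large shift in the series came only with a number 33.9 percentage points higher from compound 1 to compound 2 (beyond the scatter), a change compound 4 does not carry. A step within the scatter is therefore expected in this assay, with no clear direction.

The estimate for compound 4 is 12%, with a range from 4% to 26%, meaning an expected step of a number 2.2 percentage points higher from compound 1 to compound 4 (within the scatter).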

Compound 4, a percentage reported as activity, at one concentration (the size of the read-out at that concentration, not a potency): 12.2%
The estimate for compound 4 lay 0.2 percentage points below the measured number; the range from low to high includes it.
By their numbers in this assay, from the lowest: compounds 1, 4 and 3 (each within the scatter of the next); then compound 2.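

In this assay, trifluoromethyl in place of hydrogen on the aryl ring of the urea, meta to a trifluoromethyl group, gave a number 2.4 percentage points higher from compound 1 to compound 4 (within the scatter), so this aromatic carbon accepted a group of 4 heavy atoms with no step beyond the scatter. The earlier step on this ring, a number 4.6 percentage points higher from compound 1 to compound 3 (within the scatter), exchanged one substituted aryl group for another, whereas the new step keeps the existing trifluoromethyl and only adds a second one, which shows that added substitution on the same ring also stays within the scatter at the one concentration tested. No accompanying measurement bears on why this substitution leaves the read-out within the scatter.

The compounds shown leave open whether this carbon would accept groups of another kind, such as an amine, a carboxylic acid or a longer alkyl chain, in place of the hydrogen. They also leave open whether the same added trifluoromethyl would give a step within the scatter on the amide of compound 2, where the urea nitrogen is absent.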